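The compounds below may be only part of what the source reports. "The series", "measured", "known", "first", "only" and "open" are said of these compounds alone.

Compound 2 `COc1ccccc1N1CCN(CCCCN2CC3CCCCN3C2)CC1` is the anchor for the next step. In an assay on membranes from Cerebral cortex with Alpha-1A adrenergic receptor (Rattus norvegicus) as the target, read by radioligand binding (a higher number here means a weaker inhibitor, a lower number a stronger inhibitor), compound 2 gives 45 nM. Going by the values given here, the only other measured compound is compound 1 `COc1ccccc1N1CCN(CCCCN2CC3CCCN3C2)CC1`, which in this assay gives 72.6 nM; the change a 1.6-fold lower number from compound 1 to compound 2 (0.21 log units; within the scatter) concerns the saturated amine at the end of the chain and lies within the scatter, so the two numbers cannot be told apart. Compound 3 `Clc1cccc(N2CCN(CCCCN3CC4CCCCN4C3)CC2)c1` differs from compound 2 in another part of the molecule: 3-chlorophenyl in place of 2-methoxyphenyl on an amine nitrogen in a ring. Among the compounds with values here, no measured step touches the aryl group on the ring nitrogen, so nothing among the measured compounds bears directly on this change, and its size in this assay cannot be read from them. For compound 3 the expected step is a 2.7-fold higher number from compound 2 to compound 3 (0.43 log units; beyond the scatter). That expectation is held loosely and carries wide uncertainty in both directions. The estimated value for compound 3 is 120 nM, within the range 35 nM to 450 nM.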

Compound 3, inhibition constant: 64.3 nM
Compound 3: the middle estimate sits 1.9-fold (0.27 log units) above what was measured; the range from low to high includes it.
By their numbers in this assay, from the lowest: compounds 2, 3 and 1 (each within the scatter of the next).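

In this assay, the aryl group on the ring nitrogen now has a measured step of its own, a 1.4-fold higher number from compound 2 to compound 3 (0.15 log units; within the scatter), so 3-chlorophenyl and 2-methoxyphenyl cannot be told apart at this position. The earlier step concerned only the saturated amine at the end of the chain; this one shows that, for this pair, exchanging a group with 1 hydrogen-bond acceptor for a chlorine-bearing group with 0 leaves no readable difference in the number. No measurement is at hand that could explain this result.

This single pair does not show whether the same holds for other groups on that nitrogen, such as an unsubstituted phenyl or a pyridine ring. It also leaves open whether 3-chlorophenyl would behave the same way on the core of compound 1 or with a longer chain.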